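Swapping a carboxybenzyl for a carboxyphenylsulfonyl on the ring nitrogen

The source may report more compounds than this note shows. Statements on the series, on what has been measured and on what is new or still open speak of the compounds shown alone.

compound 1 `CC(C)c1onc(-c2c(Cl)cccc2Cl)c1COc1ccc2cc(-c3cccc(C(=O)O)c3)ccc2c1`: 130 nM
compound 2 `CC(C)c1onc(-c2c(Cl)cccc2Cl)c1COc1ccc2c(ccn2Cc2cccc(C(=O)O)c2)c1`: 210 nM

In an assay on CV-1 cells with Bile acid receptor (Homo sapiens) as the target, read by a luciferase reporter (a lower number here means that less compound is needed, a higher number that more compound is needed for the effect), compound 2 gives 210 nM and compound 1 gives 130 nM; the two numbers lie within the scatter of each other, so neither compound is set apart from the other. Compound 3 `CC(C)c1onc(-c2c(Cl)cccc2Cl)c1COc1ccc2c(ccn2S(=O)(=O)c2cccc(C(=O)O)c2)c1` differs from compound 2 by (3-carboxyphenyl)sulfonyl in place of 3-carboxybenzyl on an aromatic nitrogen. Within the data shown here, no measured pair shows a change of this kind, so its effect is not known from these data. The step of a 1.9-fold higher number from compound 2 to compound 3 (0.28 log units; within the scatter) is expected to be modest, if anything toward a higher number, and not clearly beyond the scatter. Compound 3 is accordingly estimated at 400 nM, with a range from 100 nM to 2000 nM.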

Compound 3, half-maximal effective concentration: 1300 nM
Compound 3: middle estimate off by 3.3-fold (0.51 log units), on the low side, within the range that was stated.
By their numbers in this assay, from the lowest: compounds 1 and 2 (each within the scatter of the next); then compound 3.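

Among these compounds, replacing 3-carboxybenzyl with (3-carboxyphenyl)sulfonyl on an aromatic nitrogen gives a 6.2-fold higher number from compound 2 to compound 3 (0.79 log units; beyond the scatter) in this assay, the first step at this position. Among the compounds shown here, the position is therefore not indifferent to the link that joins the carboxyphenyl ring to the nitrogen, which the earlier compounds alone could not show. No measurement here explains the step. Still open, going by these compounds, is whether a carbonyl or a longer chain as that link would stay close to compound 2 or move toward compound 3, and whether the step persists with a tetrazole in place of the carboxylic acid.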